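A few compounds are considered here, and "the series" means these few. Any claim that something is new, unique, unknown or untested is made for them only; others in the source may bear on it.

Compound 1 `OCCC#Cc1ccccc1C#Cc1ccccc1`: 12500 nM
Compound 2 `OCCCCC#Cc1ccccc1C#Cc1ccccc1`: 5220 nM
Compound 3 `OCCCCC#Cc1ccccc1C#Cc1ccccn1`: 9800 nM

These three compounds share one core and were tested in a functional assay on DU-145 cells (Homo sapiens) for cytotoxicity; on this read-out higher numbers stand for weaker inhibition of growth and lower numbers for stronger inhibition of growth. Going by the values given here, compound 2 gives the lowest of the three numbers, but its gap to compound 3 is within the scatter; only the step from compound 1 stands out, a 2.4-fold lower number from compound 1 to compound 2 (0.38 log units; beyond the scatter). The step of a 1.9-fold higher number from compound 2 to compound 3 (0.27 log units; within the scatter) shows that swapping the terminal phenyl for a pyridin-2-yl makes no difference that can be trusted.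

Compound 4 `OCCCCC#Cc1ccccc1C#Cc1cccc(C(F)(F)F)c1` is not yet measured. It differs from compound 2 in one place: trifluoromethyl in place of hydrogen on an aromatic carbon. Among the compounds with values here, no measured step involves a trifluoromethyl group, so the only guidance is the step from compound 2 to compound 3, which altered the same terminal ring and stayed within the scatter. On that basis a change at this ring is expected to move the number in this assay little, if at all, in either direction. The estimate for compound 4 is therefore 4500 nM, with a range from 1500 nM to 13000 nM, which means an expected step of a 1.2-fold lower number from compound 2 to compound 4 (0.06 log units; within the scatter) that is not beyond the scatter.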

Compound 4, concentration for 50% growth inhibition: 15300 nM
Beside the measured number, compound 4's estimate is 3.4-fold (0.53 log units) below it; measured number outside the range, above it.
By their numbers in this assay, from the lowest: compounds 2, 3, 1 and 4 (each within the scatter of the next, the first and the last beyond it).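

In this assay, the terminal ring of compound 2 proves sensitive to substitution: trifluoromethyl in place of hydrogen on an aromatic carbon, meta to a large group, gives a 2.9-fold higher number from compound 2 to compound 4 (0.47 log units; beyond the scatter). The earlier change at this ring, pyridin-2-yl in place of phenyl, gave a 1.9-fold higher number from compound 2 to compound 3 (0.27 log units; within the scatter) and so could not be told apart from the scatter, whereas this step is beyond it and points toward weaker inhibition of growth. Nothing in the data explains this shift, so the reason for it remains unknown.

From the compounds shown here alone, with only one substituent at this place, it remains open whether the higher number belongs to trifluoromethyl itself or would also appear with another group on the same carbon, such as a methyl group, a fluorine atom or an amine. Going by these compounds, it is also open whether trifluoromethyl elsewhere on this ring would give a similar step, and whether the same addition would have a similar effect on the shorter chain of compound 1.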